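Feruloyl ester of a labdane diol: expected cytotoxicity

This account rests on a few compounds, and the source may have more. Where it says the series, first, only, none or still open, it means among the compounds named here.

The shared core of compound 1 `C=CC(=C)CC[C@@H]1[C@@]2(C)CCC[C@](C)(COC(=O)/C=C/c3ccc(O)cc3)[C@@H]2CC[C@@]1(C)O` carries a cinnamate ester, and in a functional assay on HL-60 cells (Homo sapiens) for cytotoxicity, read by MTT assay, with a stated time of 48 h (a lower number here means a stronger inhibitor, a higher number a weaker inhibitor), compound 1 gives 11800 nM. For the measured compounds named here, that is the only number in the set, as the other two results are limits (the limit of > 40000 nM in this assay, at which 2 of the 3 values shown sit). Compound 2 `C=C1CC[C@@H]2[C@](C)(CCC[C@]2(C)C(=O)O)[C@H]1C/C=C(\C)C=O` reaches only the limit of the assay, > 40000 nM, in this assay. Compound 3 `C=C[C@]1(C)O[C@H]1C[C@H]1C(=C)CC[C@@H]2[C@]1(C)CCC[C@]2(C)C(=O)O` likewise reaches only the limit of the assay, > 40000 nM, in this assay. Going by the values given here, the single step between measured compounds, a step that the two limits leave unreadable from compound 2 to compound 3, therefore gives no readable size, and it concerns a different part of the core from the one altered in compound 4.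

Compound 4 `C=CC(=C)CC[C@@H]1[C@@]2(C)CCC[C@](C)(COC(=O)/C=C\c3ccc(O)c(OC)c3)[C@@H]2CC[C@@]1(C)O` differs from compound 1 by 2-(4-hydroxy-3-methoxyphenyl)ethenyl in place of 2-(4-hydroxyphenyl)ethenyl on a carbonyl carbon. Among the compounds with values here, no measured step touches this ester group, so nothing in the data argues for a change in this assay beyond the usual scatter in either direction. Compound 4 is therefore expected to sit close to compound 1, with an estimated step of a 1.0-fold higher number from compound 1 to compound 4 (0.01 log units; within the scatter). The estimate for compound 4 in this assay is 12000 nM, with a range from 4000 nM to 36000 nM.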

Compound 4, half-maximal inhibitory concentration: 9100 nM
Compound 4: middle estimate off by 1.3-fold (0.12 log units), on the high side; the measured number falls inside the stated range.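

For the compounds shown here, replacing 2-(4-hydroxyphenyl)ethenyl with 2-(4-hydroxy-3-methoxyphenyl)ethenyl on the carbonyl carbon gives the first readable step in this assay, a 1.3-fold lower number from compound 1 to compound 4 (0.11 log units; within the scatter), so this ester group takes the change without a shift beyond the scatter. The two structures are also drawn with different geometry at the ethenyl double bond, trans in compound 1 and cis in compound 4, so this single step covers both differences and cannot separate them. Nothing at hand gives a cause for the step.

The step from compound 2 to compound 3 cannot be read, since both results are limits of the assay and not numbers. From the compounds shown here alone, it remains open whether an amine on the aromatic ring, a longer chain in place of the ethenyl link, or a free alcohol in place of the whole ester would move the number beyond the scatter, and whether either double-bond geometry alone would give a different result from the other with the same aromatic group.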